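Bis-aziridinyl quinones: side-chain exchange at the ring carbon

This account rests on a few compounds, and the source may have more. Where it says the series, first, only, none or still open, it means among the compounds named here.

Measured so far:
compound 1, `CC1=C(N2CC2)C(=O)C(CC(C)OC(N)=O)=C(N2CC2)C1=O`: 5.18
compound 2, `CC(=O)C1=C(N2CC2)C(=O)C(C)=C(N2CC2)C1=O`: 3.48
compound 3, `CC1=C(N2CC2)C(=O)C(N2CC2)=C(N2CC2)C1=O`: 5.69

In a functional assay on L1210 cells (Mus musculus), with a stated time of 1 days (a higher number here means a more potent compound, by a factor of ten per unit of this negative logarithm, a lower number a less potent compound), compound 1 stands second of the three, below compound 3 and well above compound 2. Both known steps change the group on the double-bonded ring carbon of the shared core: a number 1.70 log units lower from compound 1 to compound 2 (beyond the scatter), and a number 0.51 log units higher from compound 1 to compound 3 (beyond the scatter). The position is thus sensitive, and in both directions, but neither step keeps the chain in place as compound 4, `CC1=C(N2CC2)C(=O)C(COc2ccccc2)=C(N2CC2)C1=O`, does.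

Compound 4 differs from compound 1 as follows: a group of 7 heavy atoms (6 carbon, 1 oxygen; one six-membered aromatic ring of carbon only) in place of a group of 6 heavy atoms (3 carbon, 1 nitrogen, 2 oxygen; no ring), on a saturated chain carbon bound to a double-bonded ring carbon. The change sits on a saturated chain carbon bound to a double-bonded ring carbon, so the chain itself is kept while its end is exchanged. Among the compounds with values here, no measured step isolates this exchange. Given the spread seen at this position, a modest loss is expected for compound 4 in this assay, a number 0.38 log units lower from compound 1 to compound 4 (beyond the scatter), with a wide range. The estimate for compound 4 is 4.8, between 4 and 5.6.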

Compound 4, logarithm of the reciprocal of the active concentration, log(1/C): 3.89
Estimate against measurement, compound 4: 0.91 log units above; measured number outside the range, below it.
By their numbers in this assay, from the lowest: compound 2; then compound 4; then compound 1; then compound 3.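

In this assay, the step with the saturated chain carbon kept in place is large (a number 1.29 log units lower from compound 1 to compound 4 (beyond the scatter)), so exchanging the chain end alone is enough to move the number by more than the scatter. The earlier steps shown here replaced the whole group on the double-bonded ring carbon, and they could not show that the part beyond the chain carbon matters this much on its own. Nothing measured here gives a reason for this drop.

The compounds shown do not separate a loss tied to the group that leaves from a penalty tied to the phenoxy that enters. A hydroxyl, a primary amine or a longer alkyl chain on the same saturated chain carbon would help to tell these two readings apart.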